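Replacing a carboxyphenyl with a formylphenyl on an aryl ether

The source may report more compounds than this note shows. Statements on the series, on what has been measured and on what is new or still open speak of the compounds shown alone.

Measured so far:
compound 1 `O=C(O)c1cccc(COc2ccc(OCCOCCNC3CCCC3)cc2)c1` — > 100000 nM
compound 2 `c1ccc(COc2ccc(OCCOCCNC3CCCCC3)cc2)cc1` — 7370 nM

In a functional assay on SK-OV-3 cells (Homo sapiens) for inhibition, read by CCK-8 assay, with a stated time of 70 h (a higher number here means a weaker inhibitor, a lower number a stronger inhibitor), compound 1 reaches only a limit, > 100000 nM; no number is known for it, and this limit is the limit of > 100000 nM in this assay, at which 1 of the 2 values shown sits. Compound 1 therefore stands at the weak end of what has been measured. For the measured compounds named here, compound 2 `c1ccc(COc2ccc(OCCOCCNC3CCCCC3)cc2)cc1` is the one compound with a number in this assay, giving 7370 nM.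

Compound 3 `O=Cc1ccc(COc2ccc(OCCOCCNC3CCCC3)cc2)cc1` is to be measured in this assay. It differs from compound 1 in one place, (4-formylphenyl in place of 3-carboxyphenyl on a saturated chain carbon bound to an oxygen on an aromatic ring), so that a 4-formylphenyl stands where compound 1 carries a 3-carboxyphenyl. Compound 2, which carries an unsubstituted benzyl group and gives a number, is the nearest point of reference, though it also differs in its ring amine.

Going by the values given here, no step between measured compounds is known, so what is expected rests on the two values alone. The account expects compound 3 to gain potency over compound 1 by an at least 8.3-fold lower number from compound 1 to compound 3 (0.92 log units; beyond the scatter), moving toward the region of compound 2. Compound 3 is estimated at 12000 nM, with a range from 3000 nM to 60000 nM.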

Compound 3, half-maximal inhibitory concentration: 45000 nM
Beside the measured number, compound 3's estimate is 3.8-fold (0.57 log units) below it; the measured number falls inside the stated range.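

With 4-formylphenyl in place of 3-carboxyphenyl on a saturated chain carbon bound to an oxygen on an aromatic ring, this assay shows an at least 2.2-fold lower number from compound 1 to compound 3 (0.34 log units; beyond the scatter). Compound 1 gives > 100000 nM, which is a limit and not a number, so the size of this step is known only as a bound: the limit of > 100000 nM in this assay, at which 1 of the 3 values shown sits. The kind of group and the number in its name change together, 3-carboxyphenyl leaving and 4-formylphenyl entering, so the result shows that this place on the shared core can carry a group that yields a measurable value, but it does not tell which part of the change matters.

The compounds shown leave open whether a 4-carboxyphenyl or a 3-formylphenyl at this place would separate the kind of group from where it sits on the ring, and whether a nitrile or a hydroxymethyl in place of the formyl would read like compound 3. For the compounds shown here, compound 2 differs from compound 3 in more than one place, so no step to it can be read, and the share of the unsubstituted benzyl group and of the ring amine stays unknown.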